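From 4-aminopyridin-3-yl to 6-aminopyridin-3-yl on the shared core

This account rests on a few compounds, and the source may have more. Where it says the series, first, only, none or still open, it means among the compounds named here.

In a functional assay on MCF7 cells (Homo sapiens) for cytotoxicity, read by MTT assay, with a stated time of 48 h (a higher number here means a weaker inhibitor, a lower number a stronger inhibitor), compound 1 `Cc1ccc(-c2nnc(SCCn3c([N+](=O)[O-])cnc3C)o2)cc1`, carrying 4-methylphenyl, gives 15500 nM, and compound 2 `Cc1ncc([N+](=O)[O-])n1CCSc1nnc(-c2cnccc2N)o1`, carrying 4-aminopyridin-3-yl, gives 29300 nM. For the measured compounds named here, compound 2 therefore stands within the scatter of compound 1, the only other measured member of the series. Compound 3 `Cc1ncc([N+](=O)[O-])n1CCSc1nnc(-c2ccc(N)nc2)o1` has the same atoms as compound 2, joined differently: 6-aminopyridin-3-yl in place of 4-aminopyridin-3-yl on an aromatic carbon. The exchange sits on an aromatic carbon of a five-membered aromatic ring with 2 nitrogen and 1 oxygen. Going by the values given here, the only measured step bears on this change indirectly: a 1.9-fold higher number from compound 1 to compound 2 (0.28 log units; within the scatter), for 4-aminopyridin-3-yl in place of 4-methylphenyl at that same place. Among the compounds with values here, no measured pair compares two aminopyridinyl groups, so the data offer no direct guide. With that one exchange inside the scatter, no step beyond the scatter is expected here. The estimated step is a 1.2-fold lower number from compound 2 to compound 3 (0.09 log units; within the scatter). For compound 3 the expected value is 24000 nM, with an estimated range from 10000 nM to 55000 nM.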

Compound 3, half-maximal inhibitory concentration: 26800 nM
For compound 3 the middle estimate is 1.1-fold (0.05 log units) below the measured one; the measured number falls inside the stated range.
By their numbers in this assay, from the lowest: compounds 1, 3 and 2 (each within the scatter of the next).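

In this assay, for the compounds shown here, this is the first direct comparison of two aminopyridinyl groups on the aromatic carbon of the five-membered ring, and it gives a 1.1-fold lower number from compound 2 to compound 3 (0.04 log units; within the scatter), so 4-aminopyridin-3-yl and 6-aminopyridin-3-yl, which have the same atoms and the same counts of donors and acceptors, are not separated at this place. The second aminopyridinyl group also stays level with the carbocyclic comparator, with a 1.7-fold higher number from compound 1 to compound 3 (0.24 log units; within the scatter), so the 4-methylphenyl group and both aminopyridinyl groups now lie within the scatter of one another. No measurement is available that would explain this flat result.

The compounds shown leave open whether any group at this place can produce a step beyond the scatter, for example a carboxylic acid or a chlorine atom on the phenyl ring in place of the methyl group. They also leave open how the number responds to changes elsewhere on the shared core, such as a longer chain between the sulfur and the nitroimidazole-bearing nitrogen, or an amine in place of the nitro group.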